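This account rests on a few compounds, and the source may have more. Where it says the series, first, only, none or still open, it means among the compounds named here.

In a physicochemical assay for lipophilicity, using the shake flask method, in phosphate buffer, measured as octanol-water partition, at pH 7.4 (a higher number here means a more lipophilic compound, a lower number a more polar compound), compound 1 (`C[C@@H]1CN(c2ncc(OCc3ccc(S(C)(=O)=O)cc3)cn2)[C@@H](C)CN1C(=O)OC(C)(C)C`) gives > 3.7, which is a limit and not a number. Within the data shown here, compound 2 (`Cc1cc(COc2cnc(N3CCN(C(=O)OC(C)(C)C)CC3)nc2)ccn1`) gives 3.7, the only actual number so far for the series. Among the measured compounds shown here, no measured step is available to scale from. The next compound is compound 3 (`COc1cnccc1COc1cnc(N2CCN(C(=O)OC(C)(C)C)CC2)nc1`), which differs from compound 2 in one place: 3-methoxypyridin-4-yl in place of 2-methylpyridin-4-yl on a saturated chain carbon bound to an oxygen on an aromatic ring. Here 3-methoxypyridin-4-yl stands in place of 2-methylpyridin-4-yl on a saturated chain carbon bound to an oxygen on an aromatic ring. Starting from compound 2 at 3.7, a small downward move in this assay is expected, about the size of the usual scatter, and this rests on the structural change alone. The estimated step is a number 0.30 log units lower from compound 2 to compound 3 (within the scatter). The expected value for compound 3 is 3.4, with an estimated range from 3 to 3.8.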

Compound 3, distribution coefficient: 3.8
The estimate for compound 3 lay 0.40 log units below the measured number; measured number inside the range.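

In this assay, among these compounds, 3-methoxypyridin-4-yl in place of 2-methylpyridin-4-yl on a saturated chain carbon bound to an oxygen on an aromatic ring gives the first readable step: a number 0.10 log units higher from compound 2 to compound 3 (within the scatter). Even with the oxygen and the further hydrogen-bond acceptor counted on the entering group, compound 2 and compound 3 stand within the scatter of each other, so this change does not separate them in this read-out. Compound 1 carries a limit and not a number, and gives no step to set beside this one: the limit of > 3.7 in this assay, at which 1 of the 3 values shown sits.

Open, on these data alone, is whether any group at this place moves the value beyond the scatter, for instance an amine or a carboxylic acid in place of the substituted pyridinyl group. Also open, as far as these compounds go, is whether the same change would give a similar step on the core of compound 1.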